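Methyl on the Shared Core: Predicting Compound 4

A few compounds are considered here, and "the series" means these few. Any claim that something is new, unique, unknown or untested is made for them only; others in the source may bear on it.

Compound 1, `CCC/C=C\C(=O)Nc1cc(Nc2nccc(-c3cn(C)c4ccccc34)n2)c(OC)cc1N(C)CCN(C)C`, carries the shared core of this series. In a functional assay on HepG2 cells (Homo sapiens) for antiproliferative activity, read by MTT assay, with a stated time of 72 h (on this read-out higher numbers stand for weaker inhibition and lower numbers for stronger inhibition), compound 1 gives 431 nM. Compound 2, `CCC/C=C\C(=O)Nc1cc(Nc2nc(C)cc(-c3cn(C)c4ccccc34)n2)c(OC)cc1N(C)CCN(C)C`, differs from compound 1 by one change, (methyl in place of hydrogen on an aromatic carbon), placed on an aromatic carbon of a six-membered aromatic ring with two nitrogen, next to the ring nitrogen and meta to a 1-methyl-1H-indol-3-yl group. In this assay compound 2 gives 365 nM, so that a 1.2-fold lower number from compound 1 to compound 2 (0.07 log units; within the scatter), a step that stays within the usual scatter of repeated measurements.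

Compound 3, `C=CC(=O)Nc1cc(Nc2nccc(-c3cn(C)c4ccc(F)cc34)n2)c(OC)cc1N(C)CCN(C)C`, has a different core from compound 1, and how the two cores differ is not broken down here. In this assay compound 3 gives 429 nM, a number that sits close to that of compound 1 and to that of compound 2, all within the scatter of one another.

Compound 4, `C=CC(=O)Nc1cc(Nc2nc(C)cc(-c3cn(C)c4ccc(F)cc34)n2)c(OC)cc1N(C)CCN(C)C`, is not yet measured. For the measured compounds named here, it differs from compound 3 by methyl in place of hydrogen on an aromatic carbon, the same kind of change as the one from compound 1 to compound 2, though the place is not identical: here the aromatic carbon is meta to a 5-fluoro-1-methyl-1H-indol-3-yl group rather than meta to a 1-methyl-1H-indol-3-yl group. Because a 1.2-fold lower number from compound 1 to compound 2 (0.07 log units; within the scatter) lay within the scatter, the expected step from compound 3 to compound 4 is likewise small, a 1.2-fold lower number from compound 3 to compound 4 (0.07 log units; within the scatter). The estimate for compound 4 in this assay is therefore 365 nM, expected to fall between 180 nM and 730 nM.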

Compound 4, half-maximal inhibitory concentration: 4280 nM
Compound 4: middle estimate off by 12-fold (1.07 log units), on the low side; measured number above the stated range.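

In this assay, putting methyl in place of hydrogen on an aromatic carbon has a clear effect on the core of compound 3: a 10-fold higher number from compound 3 to compound 4 (1.00 log units; beyond the scatter), which on this read-out means weaker inhibition. The same kind of change therefore did not carry over unchanged between the two cores, so the small step seen on the first core was a poor guide to the second: the same change on two cores in this assay, a 1.2-fold lower number (0.07 log units; within the scatter) from compound 1 to compound 2 and a 10-fold higher number (1.00 log units; beyond the scatter) from compound 3 to compound 4, 12-fold (1.07 log units) apart, beyond the scatter of two such steps. This shows that, in this series, the size of the methyl step can differ from one core to another, but two pairs of compounds do not show why it differs, which part of the core matters, or how the step would behave on any further core.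

On these data alone, it remains open whether the large step goes with the 5-fluoro-1-methyl-1H-indol-3-yl group or with another part of the core of compound 3. Also open, as far as these compounds go, is how an ethyl group, a chlorine atom or an amine on that same aromatic carbon would compare with hydrogen and methyl on each core.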